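Lengthening the side chain: cytotoxicity of compound 3

This account rests on a few compounds, and the source may have more. Where it says the series, first, only, none or still open, it means among the compounds named here.

Measured so far:
compound 1, `CCC[C@@H](CCn1cncn1)c1ccc(Cl)cc1`: 36.6 ug/mL
compound 2, `CCC[C@@H](CCn1cncn1)c1ccc(C)cc1`: 71.3 ug/mL

Both compounds were tested in an ADME assay on HEp-2 cells (Homo sapiens) for cytotoxicity, read by MTT assay, with a stated time of 3 days (a lower number here means that less compound is tolerated, a higher number that more compound is tolerated), so the number reports how much compound the cells tolerate. Within the data shown here, compound 2 stands at the higher of the two numbers, but the only measured step, a 1.9-fold higher number from compound 1 to compound 2 (0.29 log units; within the scatter), is within the scatter, so the two compounds cannot be ranked against each other on this evidence.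

Compound 3, `CCCC[C@@H](CCn1cncn1)c1ccc(C)cc1`, is the next compound to be measured. It differs from compound 2 by methyl in place of hydrogen on a saturated chain carbon, four bonds along the chain from an aromatic carbon. Put another way, the propyl chain of compound 2 becomes a butyl chain.

Among the measured compounds shown here, no measured step concerns the length of this chain; the one step known changes a group on the aromatic ring and is itself within the scatter. There is therefore nothing in the numbers that points to a shift in either direction. The expectation for compound 3 is a step of about a 1.2-fold lower number from compound 2 to compound 3 (0.07 log units; within the scatter), that is, no change beyond the scatter. Compound 3 is estimated to give 60 ug/mL, with a range from 30 ug/mL to 120 ug/mL.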

Compound 3, half-maximal cytotoxic concentration: 60.7 ug/mL
For compound 3 the middle estimate is 1.0-fold (0.01 log units) below the measured one; the measured number falls inside the stated range.
By their numbers in this assay, from the lowest: compounds 1, 3 and 2 (each within the scatter of the next).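

In this assay, among these compounds, the first measured change to the saturated chain, propyl to butyl, gives a 1.2-fold lower number from compound 2 to compound 3 (0.07 log units; within the scatter), whereas the only earlier step concerned a group on the aromatic ring. At this position, four bonds along the chain from an aromatic carbon, methyl in place of hydrogen therefore produces no change that can be told apart from the differences expected between repeated measurements, at least for this single added carbon. Nothing available bears on why this chain extension leaves the number within the scatter.

On these data alone, whether a longer chain such as hexyl, or a chain ending in an amine or a carboxylic acid, would move the number beyond the scatter stays open. The chloro group of compound 1 is shown only with the propyl chain, so it is also open whether the butyl chain would give a similar result with chloro in place of methyl on the aromatic ring.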